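Swapping pyridine for a dichlorophenyl ring on the oxygen

This account rests on a few compounds, and the source may have more. Where it says the series, first, only, none or still open, it means among the compounds named here.

In an ADME assay on MRC5 cells (Homo sapiens) for cytotoxicity, read by fluorescence and resazurin assay, with a stated time of 3 days (on this read-out lower numbers stand for stronger inhibition and higher numbers for weaker inhibition), the measured compounds read as follows:
Compound 1 `Cc1ccc(Oc2cccc(CN3CCC(n4cc(C)c(=O)[nH]c4=O)CC3)c2)cc1` gives > 64000 nM (a limit)
Compound 2 `COc1ccc(Oc2cccc(CN3CCC(n4cc(C)c(=O)[nH]c4=O)CC3)c2)cc1` gives 28000 nM (a number)
Compound 3 `Cc1cn(C2CCN(Cc3cccc(Oc4cccnc4)c3)CC2)c(=O)[nH]c1=O` gives > 64000 nM (a limit)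

Compound 3 stands at the limit of > 64000 nM in this assay, at which 2 of the 3 values shown sit, and so has a limit, not a number. Compound 4 `Cc1cn(C2CCN(Cc3cccc(Oc4ccc(Cl)c(Cl)c4)c3)CC2)c(=O)[nH]c1=O` carries 3,4-dichlorophenyl in place of pyridin-3-yl on an oxygen on an aromatic ring.

The closest measured change is an at least 2.2-fold higher number from compound 2 to compound 3 (0.35 log units; beyond the scatter) for pyridin-3-yl in place of 4-methoxyphenyl. Alongside it stands an at least 2.2-fold lower number from compound 1 to compound 2 (0.35 log units; beyond the scatter) for methoxy in place of methyl. The third step, a step that the two limits leave unreadable from compound 1 to compound 3, gives no size. Compound 1 goes against any simple rule, since it also carries a carbon-only ring yet gives only a limit.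

A modest step to a lower number, meaning stronger inhibition, is therefore expected, though compound 4 could stay at the limit. The estimated result is an at least 2.4-fold lower number from compound 3 to compound 4 (0.39 log units; beyond the scatter) (expected, not measured). Compound 4 is expected at 26000 nM (estimated range 9000 nM to 64000 nM).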

Compound 4, half-maximal inhibitory concentration: 6100 nM
Beside the measured number, compound 4's estimate is 4.3-fold (0.63 log units) above it, and the stated range ends above it.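

In this assay, this change on the oxygen can be large: there is an at least 10-fold lower number from compound 3 to compound 4 (1.02 log units; beyond the scatter), and measured against the 4-methylphenyl group there is an at least 10-fold lower number from compound 1 to compound 4 (1.02 log units; beyond the scatter). Against 4-methoxyphenyl, the only other group here that gives a number, there is a 4.6-fold lower number from compound 2 to compound 4 (0.66 log units; beyond the scatter), which makes compound 4 the strongest inhibitor of the four. Compound 1, which also carries a carbon-only ring, gives > 64000 nM, a limit, so a carbon-only ring does not by itself bring a number within reach.

Still open is whether both chlorines are needed, since a phenyl ring with a single chlorine is not among these compounds, and neither is a ring bearing an amine or a carboxylic acid. How large the steps from compound 1 and compound 3 really are also stays open, because those two compounds rest on a limit: the limit of > 64000 nM in this assay, at which 2 of the 4 values shown sit.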